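Swapping the aryl group on a kinase-binding core

A few compounds are considered here, and "the series" means these few. Any claim that something is new, unique, unknown or untested is made for them only; others in the source may bear on it.

Measured so far:
compound 1, `CCCS(=O)(=O)Nc1ccc(F)c(C(=O)c2n[nH]c3ncc(-c4ccccc4F)cc23)c1F`: 2%
compound 2, `CCCS(=O)(=O)Nc1ccc(F)c(C(=O)c2n[nH]c3ncc(-c4ccc(N)cc4)cc23)c1F`: 0.1%

In an assay for binding affinity to dual specificity mitogen-activated protein kinase kinase 4 (Homo sapiens), read by KINOMEscan, tested at 100 nM (a higher number here means a weaker effect of the compound at the concentration tested, a lower number a stronger effect), compound 2 gives 0.1% and is the lowest of the two numbers; its nearest neighbour is compound 1, whose value sits a number 1.9 percentage points lower from compound 1 to compound 2 (within the scatter). Compound 3, `CCCS(=O)(=O)Nc1ccc(F)c(C(=O)c2n[nH]c3ncc(-c4ccc(Cl)c(Cl)c4)cc23)c1F`, has not been measured. It differs from compound 2 only at the aromatic carbon of the shared core: 3,4-dichlorophenyl in place of 4-aminophenyl on an aromatic carbon. Among the measured compounds shown here, the one step that bears on this position, from compound 1 to compound 2, changed the group at the same place and stayed within the scatter. So no step beyond the scatter is expected, a number 0.9 percentage points higher from compound 2 to compound 3 (within the scatter). For compound 3 the expected value is 1%, with a range from 0% to 10%.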

Compound 3, a percentage reported as activity, at one concentration (the size of the read-out at that concentration, not a potency): 45%
For compound 3 the middle estimate is 44 percentage points below the measured one, outside the stated range (above it).
By their numbers in this assay, from the lowest: compounds 2 and 1 (each within the scatter of the next); then compound 3.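

In this assay, 3,4-dichlorophenyl gives a much weaker effect, with a number 44.9 percentage points higher from compound 2 to compound 3 (beyond the scatter) and with a number 43 percentage points higher from compound 1 to compound 3 (beyond the scatter) as well. So this position does respond to the choice of aryl group, which the earlier swap between 2-fluorophenyl and 4-aminophenyl, a step within the scatter, did not reveal. Nothing in the data explains this loss.

On these data alone, it remains open whether a phenyl ring with a single chlorine would behave like compound 3, or whether one with a methoxy group or a carboxylic acid would stay close to compound 1 and compound 2.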